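The source may report more compounds than this note shows. Statements on the series, on what has been measured and on what is new or still open speak of the compounds shown alone.

Working notes on the cyclohexylphenyl series, permeability track.

Three compounds have numbers in an ADME assay on MDCK-MDR1 cells (Canis lupus familiaris) for permeability, in the apical to basolateral direction, with a stated time of 180 min (a higher number here means that the compound crosses the layer faster, a lower number that the compound crosses the layer more slowly), so far. Compound 1 `CN(C)CCC(=O)Nc1ccc([C@H]2[C@@H](F)[C@@H](F)C[C@@H](F)[C@H]2F)cc1`, which carries the tetrafluorinated ring rather than the cyclohexyl group, gives 3.7 10^-6 cm/s in this assay. Compound 2 `O=C(c1ccc(C2CCCCC2)cc1)N1CC(O)C1` gives 26 10^-6 cm/s, and compound 3 `CC(C(=O)Nc1ccc(C2CCCCC2)cc1)n1cncn1` gives 29.5 10^-6 cm/s. Compound 2 therefore stands well clear of compound 1, a gap beyond the scatter, while compound 2 and compound 3 lie within the scatter of each other and cannot be placed in order.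

The next compound is compound 4 `O=C(NCc1cc[nH]n1)c1ccc(C2CCCCC2)cc1`, which is not yet measured. It differs from compound 2 in one place: ((1H-pyrazol-3-yl)methyl)amino in place of 3-hydroxyazetidin-1-yl on a carbonyl carbon. Going by the values given here, no pair of measured compounds shows a step of this kind, so nothing measured tells what it does. What can be said is that compound 3, also a secondary amide carrying a small azole, gives 29.5 10^-6 cm/s, close to compound 2.

On that basis compound 4 is expected to land in the same region, the step of a 1.3-fold lower number from compound 2 to compound 4 (0.11 log units; within the scatter) expected to be small and, if anything, downward. The estimate for compound 4 in this assay is 20 10^-6 cm/s, within a range from 8 10^-6 cm/s to 40 10^-6 cm/s.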

Compound 4, apparent permeability: 16.7 10^-6 cm/s
Compound 4: the middle estimate sits 1.2-fold (0.08 log units) above what was measured; the measured number falls inside the stated range.
By their numbers in this assay, from the lowest: compound 1; then compounds 4, 2 and 3 (each within the scatter of the next).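

Going by these compounds alone, on the carbonyl carbon whose other neighbour is an aromatic carbon, ((1H-pyrazol-3-yl)methyl)amino in place of 3-hydroxyazetidin-1-yl gives, in this assay, a 1.6-fold lower number from compound 2 to compound 4 (0.19 log units; within the scatter), the first step that can be read at this position. Exchanging a four-membered non-aromatic ring with 1 hetero atom for a five-membered aromatic ring with 2 hetero atoms therefore leaves a difference that cannot be told apart from repeat measurement, so this single change does not separate the two compounds on this read-out. No supporting measurement bears on the step, and the result stands as an observation without an explanation.

As far as these compounds go, it remains open whether any group on this carbonyl carbon moves the number beyond the scatter, for instance a plain dimethylamino group, a piperazine or a substituent carrying a carboxylic acid. Also open, from the compounds shown here alone, is how much the link to the azole matters, which a longer chain between the amide nitrogen and the pyrazole, or a phenyl ring in place of the pyrazole, would test against compound 4.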